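4-methylphenyl to 4-chlorophenyl in the series

A few compounds are considered here, and "the series" means these few. Any claim that something is new, unique, unknown or untested is made for them only; others in the source may bear on it.

Values in an ADME assay on HEK293 cells (Homo sapiens) for inhibition, read by MTT assay, with a stated time of 48 h (on this read-out lower numbers stand for stronger inhibition and higher numbers for weaker inhibition), each one a limit of the assay:
compound 1 `Cc1ccc(-c2nc3ccccn3c2Sc2ccccc2)cc1` gives > 100000 nM
compound 2 `Cc1ccc(-c2nc3ccc(C)cn3c2Sc2ccccc2)cc1` gives > 100000 nM

Compound 2 stands at > 100000 nM and that is a limit. In compound 3 `Cc1ccc2nc(-c3ccc(Cl)cc3)c(Sc3ccccc3)n2c1` chloro replaces methyl on an aromatic carbon (chloro in place of methyl on an aromatic carbon). For the measured compounds named here, both measured compounds share one limit (the limit of > 100000 nM in this assay, at which 2 of the 2 values shown sit), and the single measured step (a step that the two limits leave unreadable from compound 1 to compound 2) gives no size to carry over. In this assay no change beyond the scatter is therefore expected (a number no higher from compound 2 to compound 3 (the limit leaves the size open)), in neither direction. Compound 3 is estimated at 100000 nM with a range from 40000 nM to 200000 nM and is expected to read as a limit again.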

Compound 3, half-maximal inhibitory concentration: > 100000 nM
Compound 3 gave a limit, no number; the forecaster's own chance of this, stated with the estimate: 85%; the middle value sits exactly at the limit.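

In this assay, compound 2 and compound 3 both read as limits, so no step can be read between them: the limit of > 100000 nM in this assay, at which 3 of the 3 values shown sit.

Whether 4-methylphenyl to 4-chlorophenyl changes inhibition at all, and whether any compound shown has a readable number, stays open.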